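This account rests on a few compounds, and the source may have more. Where it says the series, first, only, none or still open, it means among the compounds named here.

Of the compounds shown here, two have so far been measured in a functional assay on A549 cells (Homo sapiens) for inhibition, read by MTT assay, with a stated time of 48 h, tested at 10 uM; on this read-out higher numbers stand for more inhibition of growth at the one concentration tested and lower numbers for less inhibition of growth. Compound 1 `O=C(/C=C/c1ccc(OCc2cn(Cc3cccc(F)c3)nn2)cc1)c1ccc(Br)cc1` gives 37%. Compound 2 `COc1ccc(C(=O)/C=C/c2ccc(OCc3cn(Cc4ccc(Br)cc4)nn3)cc2)cc1` gives 50%, the higher of the two numbers, and its gap to compound 1 is larger than the usual scatter of repeated measurements. Compound 1 and compound 2 differ from each other in more than one place, so their two numbers simply stand side by side, and no single change can be tied to the gap between them.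

Compound 3 `COc1ccc(C(=O)/C=C/c2ccc(OCc3cn(Cc4cccc(F)c4)nn3)cc2)cc1` has not yet been measured. It differs from compound 2 in one place: 3-fluorophenyl in place of 4-bromophenyl on a saturated chain carbon bound to an aromatic nitrogen. The same 3-fluorobenzyl group is already present in compound 1, whose 37% is the lower of the two measured numbers, but compound 1 also differs from compound 3 elsewhere, so this is only a faint hint. The step from compound 2 to compound 3 in this assay is expected to be small, downward if anything, and quite possibly within the scatter: a number 7 percentage points lower from compound 2 to compound 3 (within the scatter). Compound 3 is therefore estimated to give about 43%, with a likely range from 28% to 58%.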

Compound 3, percent growth inhibition at one concentration: 56%
Compound 3: middle estimate off by 13 percentage points, on the low side; the range from low to high includes it.
By their numbers in this assay, from the lowest: compound 1; then compounds 2 and 3 (each within the scatter of the next).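

In this assay, 3-fluorophenyl in place of 4-bromophenyl on a saturated chain carbon bound to an aromatic nitrogen gives a number 6 percentage points higher from compound 2 to compound 3 (within the scatter) and so leaves the two groups indistinguishable at this position, even though both the halogen and its place on the ring change. Compound 3 also forms a one-place pair with compound 1, where methoxy in place of bromo on an aromatic carbon gives a number 19 percentage points higher from compound 1 to compound 3 (beyond the scatter) and shows that the 3-fluorobenzyl group can occur with either the lower or the higher number, so the low value of compound 1 goes with its bromo group rather than with its 3-fluorobenzyl group. Nothing measured here gives a reason for either step.

Among the compounds shown here, at the chain position, only two halogen-bearing benzyl groups can be compared so far, so it remains open whether a plain benzyl group, a 4-methoxybenzyl group or a longer chain such as phenethyl would give a similar number. At the aromatic carbon, only bromo and methoxy are compared, which leaves open how a hydroxyl group or a dimethylamino group would fare.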